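This account rests on a few compounds, and the source may have more. Where it says the series, first, only, none or still open, it means among the compounds named here.

In an assay on cells for agonist activity at probable G-protein coupled receptor 34 (Mus musculus), with a stated time of 1 h (on this read-out higher numbers stand for larger maximal responses and lower numbers for smaller maximal responses), three compounds built on one shared core have been measured. Compound 1 `Cc1cccc(Oc2cccc(COc3ccccc3CCC(=O)OCCCOP(=O)(O)OC[C@H](N)C(=O)O)c2)c1` gives 21.3%. Compound 2 `N[C@@H](COP(=O)(O)OCCCOC(=O)CCc1ccccc1OCc1cccc(Oc2ccc(Cl)c(Cl)c2)c1)C(=O)O` gives 18%. Compound 3 `N[C@@H](COP(=O)(O)OCCCOC(=O)CCc1ccccc1OCc1cccc(Oc2ccc(I)cc2)c1)C(=O)O` gives 19.1%. On these numbers compound 3 stands second highest of the three, with compound 2 nearest and compound 1 furthest, and both of those gaps lie within the scatter. The three steps that connect them, a number 3.3 percentage points lower from compound 1 to compound 2 (within the scatter), a number 2.2 percentage points lower from compound 1 to compound 3 (within the scatter) and a number 1.1 percentage points higher from compound 2 to compound 3 (within the scatter), each exchange one group on an oxygen on an aromatic ring, and none of them moves the number beyond the scatter.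

Compound 4 `CCc1ccc(Oc2cccc(COc3ccccc3CCC(=O)OCCCOP(=O)(O)OC[C@H](N)C(=O)O)c2)cc1` differs from compound 3 by ethyl in place of iodo on an aromatic carbon. This is once more an exchange of a single group on that same ring, so the three measured steps bear on it directly, and all of them stayed within the scatter. No step beyond the scatter is therefore expected here. The step from compound 3 to compound 4 is estimated at a number 0.4 percentage points higher from compound 3 to compound 4 (within the scatter). Compound 4 is expected to give 19.5%, within a range from 12% to 27%.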

Compound 4, largest response reached (Emax), in percent of the reference or control that the assay uses: 19.3%
The estimate for compound 4 lay 0.2 percentage points above the measured number, within the range that was stated.
By their numbers in this assay, from the lowest: compounds 2, 3, 4 and 1 (each within the scatter of the next).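

The earlier steps shown here each exchanged a whole substituted phenyl group, whereas this one changes only the group on an aromatic carbon para to a large group, from one iodine atom to the two carbons of ethyl, and in this assay it gives a number 0.2 percentage points higher from compound 3 to compound 4 (within the scatter). The 4-ethylphenyl group also compares with the other two phenyl groups without a clear difference, with a number 1.3 percentage points higher from compound 2 to compound 4 (within the scatter) and a number 2 percentage points lower from compound 1 to compound 4 (within the scatter), so all six steps among these compounds stay within the scatter. Nothing available here offers an explanation for this flat picture.

As far as these compounds go, whether an amine, a carboxylic acid or a longer chain at this position would move the number beyond the scatter remains open. From the compounds shown here alone, the effect of changes elsewhere also remains open, as the rest of the shared core is the same in all four compounds.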